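Swapping the pyridine of compound 2 for a piperidine

The source may report more compounds than this note shows. Statements on the series, on what has been measured and on what is new or still open speak of the compounds shown alone.

Compound 1 `CCC(C)(C)Cc1c[nH]c(CCc2ccc(-c3cccc(N)n3)cc2)n1` gives 7.3 nM in an in vitro assay on CHO cells for displacement of a labelled ligand from Bombesin receptor subtype-3 (Homo sapiens), read by scintillation counting, with a stated time of 2 h; a higher number here means a weaker inhibitor, a lower number a stronger inhibitor. Among the compounds with values here, compound 2 `CCC(C)(C)Cc1c[nH]c(CCc2ccc(-c3ccncc3)cc2)n1` gives 101 nM, the highest of the two numbers so far, the change being a 14-fold higher number from compound 1 to compound 2 (1.14 log units; beyond the scatter). Compound 3 `CCC(C)(C)Cc1c[nH]c(CCc2ccc(N3CCCCC3)cc2)n1` differs from compound 2 by piperidin-1-yl in place of pyridin-4-yl on an aromatic carbon. Within the data shown here, no measured step tests this exact change; the only known step concerns a different exchange, so the size and direction here are uncertain. Compound 3 is expected near compound 2, with a step of a 2.0-fold higher number from compound 2 to compound 3 (0.30 log units; within the scatter), and an estimate of 200 nM (range 50 nM to 1000 nM).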

Compound 3, half-maximal inhibitory concentration: 28 nM
The estimate for compound 3 lay 7.1-fold (0.85 log units) above the measured number, outside the stated range (below it).
By their numbers in this assay, from the lowest: compound 1; then compound 3; then compound 2.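

On the aromatic carbon para to a large group, the ring need not be aromatic in this assay: piperidin-1-yl in place of pyridin-4-yl gives a gain (a 3.6-fold lower number from compound 2 to compound 3 (0.56 log units; beyond the scatter)). The 6-aminopyridin-2-yl of compound 1 still keeps the lower number (a 3.8-fold higher number from compound 1 to compound 3 (0.58 log units; beyond the scatter)), so the piperidine recovers only part of the gap. Nothing measured here accounts for either step. The compounds shown leave open how morpholin-4-yl would compare with piperidin-1-yl at this position, and whether an amino group on the piperidine ring would lower the number further.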